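The compounds below may be only part of what the source reports. "The series", "measured", "known", "first", "only" and "open" are said of these compounds alone.

Compound 2 `O=C(COc1ccc(C(=O)/C=C/c2ccc(F)c(F)c2)cc1)N[C@H]1CCOC1=O` gives the highest of the two numbers shown in a functional assay on PC-3 cells (Homo sapiens) for antiproliferative activity, read by MTT assay, with a stated time of 72 h (on this read-out lower numbers stand for stronger inhibition and higher numbers for weaker inhibition), and the other compound, compound 1 `O=C(COc1ccc(C(=O)/C=C/c2ccccc2Cl)cc1)N[C@H]1CCOC1=O`, gives 4610 nM in this assay. In this assay compound 2 gives 21900 nM, with a 4.8-fold higher number from compound 1 to compound 2 (0.68 log units; beyond the scatter). Compound 3 `CC(C)(C)c1ccc(/C=C/C(=O)c2ccc(OCC(=O)N[C@H]3CCOC3=O)cc2)cc1` differs from compound 2 only here: 4-(tert-butyl)phenyl in place of 3,4-difluorophenyl on a double-bonded chain carbon bound to a double-bonded chain carbon. No measured step bears on this exact change; the one step shown concerns a different swap on the same carbon and was modest. The number for compound 3 is therefore expected to stay near that of compound 2, with a 2.4-fold lower number from compound 2 to compound 3 (0.39 log units; beyond the scatter) allowed. Compound 3 is estimated at 9000 nM, ranging from 2500 nM to 35000 nM.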

Compound 3, half-maximal inhibitory concentration: 10600 nM
For compound 3 the middle estimate is 1.2-fold (0.07 log units) below the measured one; measured number inside the range.
By their numbers in this assay, from the lowest: compound 1; then compound 3; then compound 2.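

In this assay a third aryl group on this double-bonded chain carbon shifts the number again: 4-(tert-butyl)phenyl gives a 2.1-fold lower number from compound 2 to compound 3 (0.32 log units; beyond the scatter) and a 2.3-fold higher number from compound 1 to compound 3 (0.36 log units; beyond the scatter). Compound 3 therefore falls between the other two, and the 2-chlorophenyl of compound 1 still gives the lowest number. Nothing measured here explains this order. Open, going by these compounds, is what an unsubstituted phenyl would give at this carbon, which would show whether any of these groups helps or harms. A phenyl carrying an amine or a carboxylic acid also remains untested among the compounds shown.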